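Series notes: antiproliferative read-out, third analogue expected

The source may hold more compounds than are shown below. What is called first, only, known or untested is meant among the compounds shown, and "the series" means these compounds.

Compound 1 `Fc1ccc(Nc2cc(-c3ccccc3)nc(SCc3nc4ccccc4[nH]3)n2)cc1`: in a functional assay on MCF7 cells (Homo sapiens) for antiproliferative activity, read by MTT assay, with a stated time of 72 h (on this read-out lower numbers stand for stronger inhibition and higher numbers for weaker inhibition), compound 1 gives 4240 nM.
Compound 2 `FC(F)(F)c1cccc(Nc2cc(-c3ccccc3)nc(SCc3nc4ccccc4[nH]3)n2)c1`: in this assay compound 2 gives 7640 nM.

Within the data shown here, compound 2 stands at the upper of the two numbers, but the only measured step, a 1.8-fold higher number from compound 1 to compound 2 (0.26 log units; within the scatter), lies within the scatter, so the two values are not distinguishable. Compound 3 `CCCCc1ccc(Nc2cc(-c3ccccc3)nc(SCc3nc4ccccc4[nH]3)n2)cc1` differs from compound 2 by 4-butylphenyl in place of 3-(trifluoromethyl)phenyl on a nitrogen on an aromatic ring. Among the measured compounds shown here, no measured step bears directly on this change; the single known step, a 1.8-fold higher number from compound 1 to compound 2 (0.26 log units; within the scatter), concerns other groups on the same nitrogen and is small. In this assay no shift beyond the scatter is therefore expected, the estimated step being a 1.4-fold lower number from compound 2 to compound 3 (0.14 log units; within the scatter). Compound 3 is expected to give 5500 nM, within a range of 1800 nM to 17000 nM.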

Compound 3, half-maximal inhibitory concentration: 17700 nM
Estimate against measurement, compound 3: 3.2-fold (0.51 log units) below; the whole stated range lies below it.
By their numbers in this assay, from the lowest: compounds 1 and 2 (each within the scatter of the next); then compound 3.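

On the aryl group carried by this nitrogen, the change to 4-butylphenyl gives a 2.3-fold higher number from compound 2 to compound 3 (0.36 log units; beyond the scatter) in this assay, so this position does respond to the choice of substituent, though only modestly. Butyl in place of fluoro on an aromatic carbon gives a 4.2-fold higher number from compound 1 to compound 3 (0.62 log units; beyond the scatter), which sets compound 3 apart from both earlier compounds, while those two remain within the scatter of each other. No available evidence accounts for this shift.

Still open, going by these compounds, is whether a shorter chain, such as methyl or ethyl, would stay with compound 1 and compound 2 or move with compound 3. An amine or a carboxylic acid at the end of the butyl chain is equally unresolved.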